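The source may report more compounds than this note shows. Statements on the series, on what has been measured and on what is new or still open speak of the compounds shown alone.

- Compound 1 `CC(C)CC(O)(CC(C)C)[C@@H]1/C=C\C=C(\CO)C2=C([C@H]3OC(C)(C)O[C@@H]23)[C@H]1c1ccccc1`: 32400 nM
- Compound 2 `CCCCCC[C@@H]1/C=C\C=C(\CO)C2=C([C@H]3OC(C)(C)O[C@@H]23)[C@H]1c1ccccc1`: 52900 nM

In a functional assay on THP-1 cells (Homo sapiens) for activation, read by annexin V staining, with a stated time of 24 h (a lower number here means that less compound is needed, a higher number that more compound is needed for the effect), compound 2 gives 52900 nM, which lies within the usual scatter of compound 1 at 32400 nM. Compound 3 `CC1(C)O[C@@H]2C3=C(/C(CO)=C\C=C/[C@@H](CCc4ccccc4)[C@@H]3c3ccccc3)[C@@H]2O1` differs from compound 2 as follows: phenyl in place of butyl on a saturated chain carbon, two bonds along the chain from a saturated ring carbon. In words, this is phenyl in place of butyl on a saturated chain carbon, two bonds along the chain from a saturated ring carbon. For the measured compounds named here, only one measured step bears on this change, a 1.6-fold higher number from compound 1 to compound 2 (0.21 log units; within the scatter), which replaced the whole group on a saturated ring carbon. Going by the values given here, no measured compound has a phenyl in this chain, so the evidence is thin. The expected step is a 1.3-fold lower number from compound 2 to compound 3 (0.12 log units; within the scatter), which means no change beyond the scatter. The estimated value for compound 3 is 40000 nM, with an expected range of 15000 nM to 90000 nM.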

Compound 3, half-maximal effective concentration: 49300 nM
Estimate against measurement, compound 3: 1.2-fold (0.09 log units) below, and the stated range covers the measured number.
By their numbers in this assay, from the lowest: compounds 1, 3 and 2 (each within the scatter of the next).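

Phenyl in place of butyl on a saturated chain carbon, two bonds along the chain from a saturated ring carbon, gives a 1.1-fold lower number from compound 2 to compound 3 (0.03 log units; within the scatter) in this assay, so an aromatic ring in this chain leaves the number within the scatter. Replacing the whole group on a saturated ring carbon with phenethyl gives a 1.5-fold higher number from compound 1 to compound 3 (0.18 log units; within the scatter) and so also stays within the scatter, which makes the three groups at this position indistinguishable here. Nothing available accounts for this result. Still open, on these data alone, is whether an amine or a carboxylic acid on this chain would move the number beyond the scatter.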